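Methoxy to ethoxy on compound 2

The source may hold more compounds than are shown below. What is called first, only, known or untested is meant among the compounds shown, and "the series" means these compounds.

Notes on a short series read in a functional assay on A549 cells (Homo sapiens) for antiproliferative activity, read by MTT assay, with a stated time of 48 h (on this read-out higher numbers stand for weaker inhibition and lower numbers for stronger inhibition), so far. Compound 1 (`COc1ccc(-c2cncc3[nH]c(=O)n(Cc4cc(OC)c(OC)c(OC)c4)c23)cc1`) gives > 20000 nM as a limit of the assay and not a number. Among the measured compounds shown here, compound 2 (`COc1ccc(-c2cc3c(cn2)[nH]c(=O)n3-c2cc(OC)c(OC)c(OC)c2)cc1F`) gives 2020 nM as the only actual number so far, and no measured step yet connects it to a close neighbour.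

Compound 3 (`CCOc1ccc(-c2cc3c(cn2)[nH]c(=O)n3-c2cc(OC)c(OC)c(OC)c2)cc1F`) differs from compound 2 by methyl in place of hydrogen on a saturated chain carbon bound to an oxygen on an aromatic ring and so takes methoxy to ethoxy, giving 3-fluoro-4-methoxyphenyl to 4-ethoxy-3-fluorophenyl. For the measured compounds named here, with no measured step to draw on, no shift beyond the usual scatter is expected in this assay for this change, and no direction is favoured. The estimated change, a 1.1-fold higher number from compound 2 to compound 3 (0.04 log units; within the scatter) is expected to stay small. The expectation is anchored on compound 2 at 2020 nM alone. For compound 3 the estimate is 2200 nM with an expected range of 700 nM to 7000 nM in this read-out.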

Compound 3, half-maximal inhibitory concentration: 2540 nM
For compound 3 the middle estimate is 1.2-fold (0.06 log units) below the measured one; the range from low to high includes it.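

In this assay, the series now has its first measured step, and it reads a 1.3-fold higher number from compound 2 to compound 3 (0.10 log units; within the scatter). Methyl in place of hydrogen on a saturated chain carbon bound to an oxygen on an aromatic ring therefore has no effect that can be told from repeat scatter, and the position accepts methoxy to ethoxy without a readable gain or loss at this level of activity. Compound 1 remains a limit of the assay and not a number, and it enters no step: the limit of > 20000 nM in this assay, at which 1 of the 3 values shown sits.

From the compounds shown here alone, whether a longer chain such as butoxy, or an amine carried on the ethoxy chain, would also leave the number in place remains open. A single small step also leaves open whether this position can respond at all in this assay.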